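Hexylsulfanyl for Cyclohexylamino: Cytotoxicity Expected to Stay Low

A few compounds are considered here, and "the series" means these few. Any claim that something is new, unique, unknown or untested is made for them only; others in the source may bear on it.

Compound 2 `Nc1nc(NC2CCCCC2)c2ncn(/C=C3/CC3(CO)CO)c2n1` was measured in an ADME assay on Akata cells (Homo sapiens) for cytotoxicity, with a stated time of 7 days (on this read-out lower numbers stand for higher toxicity in this test and higher numbers for lower toxicity in this test), and gives only a limit of > 24000 nM there. Compound 1 `CCCCCCCCOc1nc(N)nc2c1ncn2/C=C1/CC1(CO)CO` gives in this assay a limit of > 20000 nM. Compound 3 `CCCCNc1nc(N)nc2c1ncn2/C=C1/CC1(CO)CO` gives in this assay a limit of > 24000 nM. Every value therefore sits at one of two limits, the limit of > 20000 nM in this assay, at which 1 of the 3 values shown sits, and (the limit of > 24000 nM in this assay, at which 2 of the 3 values shown sit), so the changes between these compounds, a step that the two limits leave unreadable from compound 1 to compound 2, a step that the two limits leave unreadable from compound 1 to compound 3 and a step that the two limits leave unreadable from compound 2 to compound 3, have no readable size. Compound 4 `CCCCCCSc1nc(N)nc2c1ncn2/C=C1/CC1(CO)CO` differs from compound 2 in one place: hexylsulfanyl in place of cyclohexylamino on an aromatic carbon. For the measured compounds named here, no measured step shows a change beyond the scatter, so compound 4 is expected to sit near the limit in this assay, with an estimated value of 30000 nM, between 15000 nM and 60000 nM. The step expected is a step that the limit leaves unreadable from compound 2 to compound 4.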

Compound 4, half-maximal cytotoxic concentration: > 20000 nM
Compound 4 gave a limit, no number; the forecaster's own chance of this, stated with the estimate: 85%; the middle value lies beyond the limit too.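

In this assay compound 4 gives only a limit, as do compound 1, compound 2 and compound 3, so none of the steps among them can be read. The compounds shown leave open whether hexylsulfanyl, cyclohexylamino, butylamino and octyloxy differ at all in half-maximal cytotoxic concentration.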